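The source may report more compounds than this note shows. Statements on the series, on what has been measured and on what is new or still open speak of the compounds shown alone.

In a functional assay on Molt4/C8 cells (Homo sapiens) for inhibition (on this read-out higher numbers stand for weaker inhibition and lower numbers for stronger inhibition), compound 1 `COc1cccc(/C=C2\CCCc3ccccc3C2=O)c1OC` gives > 500000 nM, which is a limit of the assay and not a number. Compound 1 therefore sits at the limit of > 500000 nM in this assay, at which 2 of the 3 values shown sit. Compound 3 `O=C1/C(=C/c2ccc(Cl)cc2Cl)CCCc2ccccc21` gives > 500000 nM, which is also a limit. Among the measured compounds shown here, compound 2 `O=C1/C(=C/c2ccccc2Cl)Cc2ccccc21` is the only one with a true number, 128000 nM. Compound 4 `COc1ccccc1/C=C1\CCCc2ccccc2C1=O` differs from compound 1 by one change: hydrogen in place of methoxy on an aromatic carbon. For the measured compounds named here, no measured pair shows this change alone, so only a modest move towards stronger inhibition is expected, and the estimated step is an at least 1.4-fold lower number from compound 1 to compound 4 (0.15 log units; that floor lies within the scatter). For compound 4 the expected value is 350000 nM, with an estimated range of 120000 nM to 800000 nM.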

Compound 4, half-maximal inhibitory concentration: 37100 nM
Compound 4: the middle estimate sits 9.4-fold (0.97 log units) above what was measured; measured number below the stated range.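

Taking away this one methoxy group, on an aromatic carbon ortho to a second methoxy group, gives an at least 13-fold lower number from compound 1 to compound 4 (1.12 log units; beyond the scatter) in this assay. This place on the ring is therefore not a neutral one: on this shared core, a single methoxy group makes the difference between a limit and a true number. The step is only a floor, because one end of it is a limit: the limit of > 500000 nM in this assay, at which 2 of the 4 values shown sit.

On these data alone, whether a hydroxyl or an amine at this place would keep the inhibition seen with compound 4 stays open. So does what the remaining methoxy group contributes.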